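The source may hold more compounds than are shown below. What is called first, only, known or untested is meant among the compounds shown, and "the series" means these compounds.

Measured so far:
compound 1, `CO[C@H]1CC[C@H](NC(=O)c2n[nH]cc2NC(=O)c2cc(Cl)cc(Cl)c2)CC1` — 13000 nM
compound 2, `COc1cccc(OC)c1C(=O)Nc1c[nH]nc1C(=O)NCc1ccccc1` — 50000 nM

For the measured compounds named here, in an ADME assay on MRC5 cells (Homo sapiens) for inhibition, with a stated time of 72 h (a higher number here means that more compound is needed for the effect, a lower number that less compound is needed), compound 2 gives 50000 nM, the highest of the two numbers known; compound 1 gives 13000 nM, and the gap between them lies beyond the usual scatter. Compound 3, `COc1cccc(OC)c1C(=O)Nc1c[nH]nc1C(=O)NC1CCC(C)CC1`, has not been measured yet. It differs from compound 2 in one place: 4-methylcyclohexyl in place of benzyl on an amide-type nitrogen. Going by the values given here, no comparable step between measured compounds is available, so the effect of this change is uncertain. The expected step of a 1.3-fold lower number from compound 2 to compound 3 (0.10 log units; within the scatter) is small and not clearly beyond the scatter. Compound 3 is therefore estimated at 40000 nM, with a range from 15000 nM to 100000 nM.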

Compound 3, half-maximal effective concentration: 45000 nM
The estimate for compound 3 lay 1.1-fold (0.05 log units) below the measured number; the range from low to high includes it.
By their numbers in this assay, from the lowest: compound 1; then compounds 3 and 2 (each within the scatter of the next).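

In this assay, for the compounds shown here, placing 4-methylcyclohexyl instead of benzyl on the amide-type nitrogen gives a 1.1-fold lower number from compound 2 to compound 3 (0.05 log units; within the scatter) and provides the first reading of a change at this position. In this pair, a non-aromatic carbon ring replaces an aromatic one of equal heavy-atom count with no shift beyond the scatter. Nothing available explains this result. Still open, from the compounds shown here alone, is whether a longer carbon chain, or a group carrying an amine or a carboxylic acid, would move the number at this nitrogen. This single pair also cannot show whether the same swap would behave alike on a different core.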